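A few compounds are considered here, and "the series" means these few. Any claim that something is new, unique, unknown or untested is made for them only; others in the source may bear on it.

Measured compounds:
- compound 1, `O=S(=O)(NCCCCNCc1ccc(Br)cc1)c1cc(C(F)(F)F)cc(C(F)(F)F)c1`, giving 1900 nM in a functional assay on Capan-2 cells (Homo sapiens) for inhibition, read by MTT assay, with a stated time of 72 h; on this read-out lower numbers stand for stronger inhibition of growth and higher numbers for weaker inhibition of growth
- compound 2, `O=S(=O)(NCCCNCc1ccc(C(F)(F)F)cc1)c1cc(C(F)(F)F)cc(C(F)(F)F)c1`, giving 2000 nM in this assay

Compound 1 carries the lower of the two numbers in this assay, yet the gap to compound 2 lies within the scatter of repeated measurements, so the two compounds cannot be told apart on these values. The unmeasured compound 3, `CN(CCCNS(=O)(=O)c1cc(C(F)(F)F)cc(C(F)(F)F)c1)Cc1ccccc1`, differs from compound 1 as follows: benzyl(methyl)amino in place of ((4-bromobenzyl)amino)methyl on a saturated chain carbon, three bonds along the chain from a sulfonamide nitrogen. Going by the values given here, no step between two measured compounds is available to anchor this change, so the expectation rests only on the closeness of the two measured values. Compound 3 is expected to give a number near those of the measured pair, with at most a modest rise, and the step of a 1.8-fold higher number from compound 1 to compound 3 (0.27 log units; within the scatter) is estimated to lie near the edge of the usual scatter. For compound 3 the estimate in this assay is 3500 nM, with a range from 1400 nM to 10000 nM.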

Compound 3, concentration for 50% growth inhibition: 46000 nM
Compound 3: the middle estimate sits 13-fold (1.12 log units) below what was measured; measured number above the stated range.
By their numbers in this assay, from the lowest: compounds 1 and 2 (each within the scatter of the next); then compound 3.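

In this assay, benzyl(methyl)amino in place of ((4-bromobenzyl)amino)methyl on a saturated chain carbon, three bonds along the chain from a sulfonamide nitrogen, gives a 24-fold higher number from compound 1 to compound 3 (1.38 log units; beyond the scatter). This shows that the growth-inhibition read-out responds strongly to a change at this position, something the two earlier compounds could not show, and the change takes the count of hydrogen-bond donors in the group from 1 to 0. No measurement at hand bears on what lies behind this rise.

The step bundles the loss of the bromine with the other differences between the two groups, so the compounds shown leave open which of them carries the rise. A plain benzylamino group or a 4-bromobenzyl(methyl)amino group at this place would help to separate these differences.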